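A few compounds are considered here, and "the series" means these few. Any claim that something is new, unique, unknown or untested is made for them only; others in the source may bear on it.

Compound 1 `Cc1ccc(S(=O)(=O)NCc2ccc(CNC(=O)c3ccc(Cl)cc3)cc2)cc1` gives 10 nM in an assay on MDA-MB-231 cells for binding affinity to C-X-C chemokine receptor type 4 (Homo sapiens), read by immunofluorescence and microscopy, with stated times of 10 min and 30 min (on this read-out lower numbers stand for an effect already at smaller amounts and higher numbers for an effect only at larger amounts of compound), and compound 2 `Cc1ccc(S(=O)(=O)NCc2ccc(CNC(=O)c3ccccc3F)cc2)cc1` gives 1000 nM; on these two numbers compound 2 stands highest, with compound 1 the nearest. Going by the values given here, the one measured step, a 100-fold higher number from compound 1 to compound 2 (2.00 log units; beyond the scatter), is large. Compound 3 `Cc1ccc(S(=O)(=O)NCc2ccc(CNC(=O)c3cccc(F)c3)cc2)cc1` differs from compound 2 by 3-fluorophenyl in place of 2-fluorophenyl on a carbonyl carbon. Among the compounds with values here, no measured step changes the position of a fluorine on this ring, so the direction is uncertain; since the only change on this ring moved the number far, the number for compound 3 is expected to move too, and the estimated step of a 6.7-fold lower number from compound 2 to compound 3 (0.82 log units; beyond the scatter) is a partial return. Compound 3 is expected to give 150 nM, with a range of 20 nM to 1500 nM.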

Compound 3, effective concentration (reported as EC, without a stated level of effect): 1 nM
Estimate against measurement, compound 3: 150-fold (2.18 log units) above, outside the stated range (below it).
By their numbers in this assay, from the lowest: compound 3; then compound 1; then compound 2.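

The same atoms, joined differently, give a 1000-fold lower number from compound 2 to compound 3 (3.00 log units; beyond the scatter) in this assay, so the place of the fluorine on this ring governs the number here, at least between these two groups. The 3-fluorophenyl group also goes past the 4-chlorophenyl group, with a 10-fold lower number from compound 1 to compound 3 (1.00 log units; beyond the scatter), so the first step had not shown the lowest number this position can reach. Nothing available explains why the place of the fluorine matters so much.

The compounds shown leave open whether the halogen or its place on the ring decides the number, which a 3-chlorophenyl or a 4-fluorophenyl group would help separate. They also leave open how a methoxy group or an amine would fare on this ring.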